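Chloro on the outer ring of a biphenyl aniline

The source may report more compounds than this note shows. Statements on the series, on what has been measured and on what is new or still open speak of the compounds shown alone.

Measured compounds:
compound 1 `Oc1ccccc1CNc1ccc(F)cc1` — "not active" (no number reported)
compound 2 `Oc1ccccc1CNc1ccc(-c2ccccc2)cc1` — 1820 nM

In a functional assay on Jurkat cells (Homo sapiens) for activation, with a stated time of 24 h (on this read-out higher numbers stand for an effect only at larger amounts of compound and lower numbers for an effect already at smaller amounts), compound 1 gives "not active" (no number reported) and no number is reported. Going by the values given here, compound 2 gives 1820 nM in this assay and stands as the only compound with a number, so no step between measured compounds can be drawn. Compound 3 `Oc1ccccc1CNc1ccc(-c2ccc(Cl)cc2)cc1` differs from compound 2 by chloro in place of hydrogen on an aromatic carbon. Among the compounds with values here, with no measured step to lean on, the expected step of a 1.5-fold lower number from compound 2 to compound 3 (0.18 log units; within the scatter) is estimated as small, lying within the scatter or a little beyond it. Compound 3 is expected to give 1200 nM in this assay, within a range from 400 nM to 4000 nM.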

Compound 3, half-maximal effective concentration: 2390 nM
Compound 3: the middle estimate sits 2.0-fold (0.30 log units) below what was measured; the range from low to high includes it.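

In this assay, putting chloro in place of hydrogen on this aromatic carbon, para to a large group, gives a 1.3-fold higher number from compound 2 to compound 3 (0.12 log units; within the scatter) and so leaves phenyl and 4-chlorophenyl indistinguishable on this read-out. Going by these compounds alone, this is the first step between two numbers, and it shows that this position accepts a chloro with no reading apart from hydrogen. No evidence on this result is available. As far as these compounds go, whether an amine, a carboxylic acid or a methoxy group at this position would read the same remains open, as does the effect of chloro elsewhere on the outer ring.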